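Phenyl to 4-bromophenyl on compound 2

The source may hold more compounds than are shown below. What is called first, only, known or untested is meant among the compounds shown, and "the series" means these compounds.

In a functional assay on MCF7 cells (Homo sapiens) for antiproliferative activity, read by MTT assay, with a stated time of 48 h (on this read-out lower numbers stand for stronger inhibition and higher numbers for weaker inhibition), compound 1 (`CC(=O)Oc1c(Br)cc(Br)cc1/C=C1\N=C(c2ccccc2)N(C(N)=S)NC1=O`) gives 28500 nM and compound 2 (`CC(=O)Oc1c(Br)cc(Br)cc1/C=C1\N=C(c2ccccc2)N(c2ncc(-c3ccccc3)s2)NC1=O`) gives 38300 nM. These two values lie within the scatter of each other, so compound 2 cannot be separated from compound 1 on the numbers available.

Compound 3 (`CC(=O)Oc1c(Br)cc(Br)cc1/C=C1\N=C(c2ccccc2)N(c2ncc(-c3ccc(Br)cc3)s2)NC1=O`) carries bromo in place of hydrogen on an aromatic carbon of compound 2, para to a large group: bromo in place of hydrogen on an aromatic carbon. Going by the values given here, no measured step tests bromo at this place. Among the compounds with values here, the only measured step, a 1.3-fold higher number from compound 1 to compound 2 (0.13 log units; within the scatter), exchanged a much larger group on an amine nitrogen in a ring, and it stayed within the scatter. It bears only indirectly, and on that basis no step beyond the scatter is expected in this assay. The expected change is a 1.2-fold lower number from compound 2 to compound 3 (0.08 log units; within the scatter). The estimate for compound 3 is 32000 nM, with an estimated range of 13000 nM to 65000 nM.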

Compound 3, half-maximal inhibitory concentration: 9490 nM
For compound 3 the middle estimate is 3.4-fold (0.53 log units) above the measured one; the whole stated range lies above it.
By their numbers in this assay, from the lowest: compound 3; then compounds 1 and 2 (each within the scatter of the next).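

In this assay, going by these compounds alone, phenyl to 4-bromophenyl gives a 4.0-fold lower number from compound 2 to compound 3 (0.61 log units; beyond the scatter), the first step beyond the scatter, so this place on the six-membered aromatic ring of carbon only responds to a single bromo in place of hydrogen. The larger exchange on the amine nitrogen in a ring separates from the group it replaces only once bromo is present: a 3.0-fold lower number from compound 1 to compound 3 (0.48 log units; beyond the scatter) stands beyond the scatter, while a 1.3-fold higher number from compound 1 to compound 2 (0.13 log units; within the scatter) stays within it. No measurement at hand accounts for the bromo step.

On these data alone, whether chloro, methoxy or an amine at the same place gives a step of similar size remains open. Bromo elsewhere on that ring would show whether the step follows the group or the place.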